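This account rests on a few compounds, and the source may have more. Where it says the series, first, only, none or still open, it means among the compounds named here.

Compound 1 (`Cc1ccc(-c2c(C)noc2C)cc1S(=O)(=O)NC1CCCC1`): 1590 nM
Compound 2 (`Cc1noc(C)c1-c1cc(-c2c(C3CC3)n[nH]c2C)c2[nH]c(C3CC3)nc2c1`): 8 nM
Compound 3 (`Cc1noc(C)c1-c1cc(-c2c(C)noc2C)c2nc(C3CC3)[nH]c2c1`): 80 nM

In a functional assay on MT4 cells (Homo sapiens) for cytotoxicity, read by CellTiter-Glo, with a stated time of 5 days (on this read-out higher numbers stand for an effect only at larger amounts of compound and lower numbers for an effect already at smaller amounts), compound 1 has the highest of the three numbers. Compound 3 lies lower and compound 2 lower still, and both gaps from compound 1 are beyond the scatter.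

Compound 4 (`Cc1ccc(-c2c(C)n[nH]c2C)cc1S(=O)(=O)NC1CCCC1`) differs from compound 1 in one place (3,5-dimethyl-1H-pyrazol-4-yl in place of 3,5-dimethyl-1,2-oxazol-4-yl on an aromatic carbon): 3,5-dimethyl-1H-pyrazol-4-yl in place of 3,5-dimethyl-1,2-oxazol-4-yl, on an aromatic carbon para to a methyl group.

Going by the values given here, no measured pair isolates this exchange. Compound 2 and compound 3 differ from compound 1 in far more than this group, so neither gives a direct size for it, and the expectation rests on the modest nature of a single exchange between two rings of equal size. Expected is a small step (a 1.6-fold lower number from compound 1 to compound 4 (0.20 log units; within the scatter)) that stays within the scatter and leans toward a lower number. Compound 4 is expected at 1000 nM (estimated range 300 nM to 3500 nM).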

Compound 4, half-maximal effective concentration: 5420 nM
Estimate against measurement, compound 4: 5.4-fold (0.73 log units) below; the whole stated range lies below it.
By their numbers in this assay, from the lowest: compound 2; then compound 3; then compound 1; then compound 4.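

In this assay, replacing 3,5-dimethyl-1,2-oxazol-4-yl with 3,5-dimethyl-1H-pyrazol-4-yl on the aromatic carbon para to a methyl group gives a 3.4-fold higher number from compound 1 to compound 4 (0.53 log units; beyond the scatter) as a direct size for this change. The position is therefore sensitive to the identity of the ring, even though both groups have the same heavy-atom count and differ in their hydrogen-bond donor and acceptor counts. No measured evidence bears on the origin of this step.

Going by these compounds alone, whether the step carries over to the core shared by compound 2 and compound 3 remains open, as no single-place pair on that core is available here. Also open, as far as these compounds go, is how this position responds when the five-membered ring gives way to a simple amine, a carboxylic acid or a longer alkyl chain.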